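This account rests on a few compounds, and the source may have more. Where it says the series, first, only, none or still open, it means among the compounds named here.

Compound 1 `Cc1coc(-c2ccc3c(c2O)CCCC3(C)C)c1CO` gives 39.5 uM
Compound 2 `CCOc1c(-c2occ(C)c2CO)ccc2c1CCCC2(C)C` gives 39.8 uM

In a functional assay on MDA-MB-231 cells (Homo sapiens) for cytotoxicity, read by sulforhodamine B assay, with a stated time of 3 days (on this read-out higher numbers stand for an effect only at larger amounts of compound and lower numbers for an effect already at smaller amounts), compound 1 stands level with compound 2, and the value of compound 2 at 39.8 uM lies within the scatter of the other. Compound 3 `COc1c(-c2occ(C)c2CO)ccc2c1CCCC2(C)C` carries one change from compound 2 (hydrogen in place of methyl on a saturated chain carbon bound to an oxygen on an aromatic ring), with hydrogen in place of methyl on a saturated chain carbon bound to an oxygen on an aromatic ring, ethoxy to methoxy. Among the measured compounds shown here, the only measured step bearing on this put ethyl in place of hydrogen on an oxygen on an aromatic ring (a 1.0-fold higher number from compound 1 to compound 2 (0.00 log units; within the scatter)) and stayed within the scatter. No shift beyond the scatter is therefore expected, in either direction. The expected step is small (a 1.1-fold lower number from compound 2 to compound 3 (0.03 log units; within the scatter)). For compound 3 the estimated value is 37 uM (range 19 uM to 70 uM).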

Compound 3, concentration for half-maximal effect: 28.3 uM
The estimate for compound 3 lay 1.3-fold (0.12 log units) above the measured number; the measured number falls inside the stated range.
By their numbers in this assay, from the lowest: compounds 3, 1 and 2 (each within the scatter of the next).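

In this assay, the change from ethoxy to methoxy gives a 1.4-fold lower number from compound 2 to compound 3 (0.15 log units; within the scatter), and methyl in place of hydrogen on an oxygen on an aromatic ring gives a 1.4-fold lower number from compound 1 to compound 3 (0.14 log units; within the scatter). With the earlier ethyl step, this means that hydrogen, methyl and ethyl on this oxygen all stand level, with no step beyond the scatter. No supporting measurement bears on why this position reads so flat. From the compounds shown here alone, whether a longer chain on this oxygen, or an amine or carboxylic acid at the end of such a chain, would move the number beyond the scatter remains open.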